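This account rests on a few compounds, and the source may have more. Where it says the series, first, only, none or still open, it means among the compounds named here.

Measured so far in a functional assay on MIA PaCa-2 cells (Homo sapiens) for antiproliferative activity, read by sulforhodamine B assay, with a stated time of 48 h; a higher number here means a weaker inhibitor, a lower number a stronger inhibitor

Compound 1 `COc1ccc2nc(-c3ccc(N/C=C\C(=O)c4cc(OC)c(OC)c(OC)c4)c(C)c3)sc2c1` gives 10000 nM

Compound 2 `COc1ccc2nc(-c3ccc(N/C=C\C(=O)c4cc(OC)c(OC)c([N+](=O)[O-])c4)cc3)sc2c1` gives 25600 nM

Compound 2 (25600 nM) holds the higher of the two numbers, which marks it as the weaker inhibitor, and its gap to compound 1 lies beyond the scatter. Compound 3 `COc1ccc2nc(-c3ccc(N/C=C\C(=O)c4cc(OC)c(OC)c([N+](=O)[O-])c4)c(C)c3)sc2c1` has not yet been measured. It is compound 2 with one change (methyl in place of hydrogen on an aromatic carbon), methyl in place of hydrogen on an aromatic carbon. Going by the values given here, no measured pair shows this change alone, so the size of its effect is not known. Compound 1 (10000 nM) carries the same methyl but also differs from compound 2 elsewhere, so it offers only a weak hint. A small step toward a lower number is expected in this assay and it may stay within the scatter. The estimated move (a 1.6-fold lower number from compound 2 to compound 3 (0.20 log units; within the scatter)) is modest. Compound 3 is expected at 16000 nM (estimated range 6000 nM to 40000 nM).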

Compound 3, half-maximal inhibitory concentration: 12000 nM
For compound 3 the middle estimate is 1.3-fold (0.12 log units) above the measured one; the measured number falls inside the stated range.
By their numbers in this assay, from the lowest: compounds 1 and 3 (each within the scatter of the next); then compound 2.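

In this assay, going by these compounds alone, the methyl on the aromatic carbon, ortho to a large group, gives a 2.1-fold lower number from compound 2 to compound 3 (0.33 log units; beyond the scatter) and this is the first direct reading of that change alone: a modest gain that lies beyond the scatter. With this methyl present, nitro in place of methoxy gives a 1.2-fold higher number from compound 1 to compound 3 (0.08 log units; within the scatter) and that step is within the scatter, so compound 1 and compound 3 cannot be told apart here. No measurement shown explains why the methyl shifts the number.

On these data alone, it remains open whether an ethyl group or a chlorine atom at this same carbon would move the number further. As far as these compounds go, it is also open whether the methyl gives a similar step when methoxy replaces the nitro group, since only the nitro series shows this change alone.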